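The source may hold more compounds than are shown below. What is called first, only, known or untested is meant among the compounds shown, and "the series" means these compounds.

Measured so far in a functional assay on cells (Platelet, Homo sapiens) for inhibition; on this read-out higher numbers stand for weaker inhibition and lower numbers for stronger inhibition:

Compound 1 `CCCn1nc(-c2ccc(C(=O)OCC)cc2)c2ccccc21` gives > 10000 nM in this assay, which is a limit of the assay and not a number.
Compound 2 `CCCCn1nc(-c2ccc(C(=O)OCC)cc2)c2ccccc21` gives > 10000 nM in this assay, again a limit and not a number.
Compound 3 `CNC(=O)c1ccc(-c2nn(Cc3ccccc3)c3ccccc23)cc1` gives > 10000 nM in this assay, likewise a limit and not a number.

Compounds 1 and 2 share a core and differ by methyl in place of hydrogen on a saturated chain carbon, three bonds along the chain from an aromatic nitrogen. The step from the first to the second is a step that the two limits leave unreadable from compound 1 to compound 2; its size cannot be read, because both ends sit at the limit of > 10000 nM in this assay, at which 3 of the 3 values shown sit. How the core of compound 3 relates to the core of compound 1 is not broken down here.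

Compound 4 `CCNC(=O)c1ccc(-c2nn(Cc3ccccc3)c3ccccc23)cc1` is not yet measured. It differs from compound 3 by methyl in place of hydrogen on a saturated chain carbon bound to an amide-type nitrogen. Among the compounds with values here, this is the same kind of change as the one from compound 1 to compound 2, though the place is not the same: there the methyl enters on a saturated chain carbon three bonds along the chain from an aromatic nitrogen, here on a saturated chain carbon bound to an amide-type nitrogen.

The expectation for compound 4 rests on the three measured compounds, all of which sit at the limit of > 10000 nM in this assay, at which 3 of the 3 values shown sit, and on the unreadable step that the two limits leave unreadable from compound 1 to compound 2. On that basis compound 4 is expected to give 15000 nM in this assay, with an estimated range of 5000 nM to 60000 nM. The step expected from compound 3 to compound 4 is estimated at a step that the limit leaves unreadable from compound 3 to compound 4, and the likeliest outcome is that compound 4 is also reported only as a limit.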

Compound 4, half-maximal inhibitory concentration: > 10000 nM
Compound 4 gave a limit, no number (the forecaster's own chance of this, stated with the estimate: 85%); the middle value is on the limit's open side.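

In this assay compound 4 gives > 10000 nM, a limit of the assay and not a number. Compound 3 also sits at a limit, so the change from compound 3 to compound 4 cannot be read as a step. The compounds shown leave open which structural change, if any, gives a measurable inhibition, since none of them departs from one limit: the limit of > 10000 nM in this assay, at which 4 of the 4 values shown sit.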